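This account rests on a few compounds, and the source may have more. Where it says the series, first, only, none or still open, it means among the compounds named here.

Compounds measured so far:
compound 1, `C=CCc1cc(OC)c(O[C@H](C)[C@@H](OCC)c2ccc(O)c(OC)c2)c(OC)c1`, in an assay on HEK293 cells for agonist activity at transient receptor potential cation channel subfamily M member 8 (Homo sapiens), read by fluorescence and calcium flux, with a stated time of 5 min (a higher number here means that more compound is needed for the effect, a lower number that less compound is needed), gives 1150 nM
compound 2, `C=CCc1cc(OC)c(O[C@H](C)[C@@H](OC(C)=O)c2ccc(O)c(OC)c2)c(OC)c1`, in this assay gives only a limit, > 10000 nM

Among the measured compounds shown here, compound 1 stands as the only compound with a number in this assay. For compound 2 the result is a limit of the assay and not a number; this limit is described in the limit of > 10000 nM in this assay, at which 1 of the 2 values shown sits. For the measured compounds named here, the one measured step, an at least 8.6-fold higher number from compound 1 to compound 2 (0.93 log units; beyond the scatter), concerns an acetyl in place of ethyl on an oxygen on a saturated carbon.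

Compound 3, `C=CCc1cc(OC)c(O[C@@H](C)[C@H](OCC)c2ccc(O)c(OC)c2)c(OC)c1`, is not yet measured. Its relation to compound 1 is the two compounds have the same atoms and bonds and differ only in configuration as drawn: 2 of 2 stereo elements differ (all stereocentres are inverted: mirror images); a stereocentre at a saturated chain carbon is drawn R in compound 1 and S in compound 3; a stereocentre at a saturated chain carbon is drawn S in compound 1 and R in compound 3. Going by the values given here, no measured step changes configuration, so none bears directly on this change, and the measured step gives no guide to its size or direction. Compound 3 is therefore estimated with a wide range, centred on a somewhat higher number, a 2.6-fold higher number from compound 1 to compound 3 (0.42 log units; beyond the scatter). For compound 3 the expected value in this assay is 3000 nM, between 700 nM and 15000 nM.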

Compound 3, half-maximal effective concentration: 1130 nM
For compound 3 the middle estimate is 2.7-fold (0.42 log units) above the measured one; the range from low to high includes it.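

Inverting both stereocentres gives a 1.0-fold lower number from compound 1 to compound 3 (0.01 log units; within the scatter) in this assay, so for the ethyl ether the two mirror images cannot be told apart here. Among the compounds shown here, this is the first measured change of configuration, and its size contrasts with the swap at the oxygen on the saturated carbon, where the step, which rests on a limit of the assay for compound 2, is an at least 8.6-fold higher number from compound 1 to compound 2 (0.93 log units; beyond the scatter). The reading involves no other structural change, and it rests on one fact: the fact that compounds 1 and 3 differ only in the configuration as drawn

What the compounds shown leave open is whether inverting only one of the two stereocentres would give a similar number, since both change together here. They also leave open how a free hydroxyl or a longer chain in place of the ethyl on that oxygen would read in this assay.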